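This account rests on a few compounds, and the source may have more. Where it says the series, first, only, none or still open, it means among the compounds named here.

Compound 1 `COc1cccc(CCOc2ccc(-c3c(C)nc(C)c([C@H](OC(C)(C)C)C(=O)O)c3N3CCC(C)(C)CC3)cc2)c1` is the reference point of this set. In an ADME assay on microsomes from liver (Rattus norvegicus) for metabolic stability, read by LC-MS, tested at 0.5 uM (on this read-out lower numbers stand for a shorter-lived compound and higher numbers for a longer-lived compound), compound 1 gives > 2 h, which is a limit of the assay and not a number. Compound 2 `Cc1nc(C)c([C@H](OC(C)(C)C)C(=O)O)c(N2CCC(C)(C)CC2)c1-c1ccc(OCCc2cc(F)c(F)cc2F)cc1` carries 2,4,5-trifluorophenyl in place of 3-methoxyphenyl on a saturated chain carbon, two bonds along the chain from an oxygen on an aromatic ring. In this assay compound 2 gives > 2 h, again only a limit. Compound 3 `Cc1nc(C)c([C@H](OC(C)(C)C)C(=O)O)c(N2CCC(C)(C)CC2)c1-c1ccc(OCCCc2ccc(F)cc2)cc1` carries 4-fluorobenzyl in place of 3-methoxyphenyl on a saturated chain carbon, two bonds along the chain from an oxygen on an aromatic ring. In this assay compound 3 gives > 2 h, also a limit. The steps a step that the two limits leave unreadable from compound 1 to compound 2, a step that the two limits leave unreadable from compound 1 to compound 3 and a step that the two limits leave unreadable from compound 2 to compound 3 thus have no readable size; all that is known is the limit of > 2 h in this assay, at which 3 of the 3 values shown sit.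

Compound 4 `Cc1ccc(CCOc2ccc(-c3c(C)nc(C)c([C@H](OC(C)(C)C)C(=O)O)c3N3CCC(C)(C)CC3)cc2)s1` is the unmeasured member. Relative to compound 1 the change is 5-methylthiophen-2-yl in place of 3-methoxyphenyl on a saturated chain carbon, two bonds along the chain from an oxygen on an aromatic ring. Three exchanges of the aromatic group at this place have each left the half-life at the limit, so no step beyond the scatter is expected from compound 1 to compound 4 in this assay, estimated as a step that the limit leaves unreadable from compound 1 to compound 4, most likely reported once more as a limit. Compound 4 is expected to give about 3 h in this assay, with a range from 1.5 h to 6 h.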

Compound 4, half-life: > 2 h
Compound 4 ended at the assay's limit; the forecaster's own chance of this, stated with the estimate: 80%; the middle value lies beyond the limit too.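

Going by these compounds alone, compound 4 sits at the same limit as compound 1, compound 2 and compound 3, so no step to compound 4 can be read: the limit of > 2 h in this assay, at which 4 of the 4 values shown sit. On these data alone, what remains open is how far the half-lives of these four compounds lie past that limit in this assay, and whether exchanging the aromatic group at this place changes them at all.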